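Adding Chlorine to a Compound Showing No Inhibition

This account rests on a few compounds, and the source may have more. Where it says the series, first, only, none or still open, it means among the compounds named here.

Compound 1, `COc1ccc(C2CC(c3ccccc3)=NN2C(=O)c2ccco2)cc1`, gives 0% in an assay on isolated protein for inhibition of DNA topoisomerase 1 (Homo sapiens), with a stated time of 30 min, tested at 100 uM; on this read-out higher numbers stand for more inhibition at the one concentration tested (going by the name of the read-out) and lower numbers for less inhibition.
Compound 2, `COc1ccc(C2CC(c3ccccc3)=NN2C(=O)c2nc3ccccc3s2)cc1`, gives 0% in this assay.

Both measured compounds share one core and differ only in the group on the carbonyl carbon. The step of no change at the digits printed from compound 1 to compound 2 (within the scatter) placed 1,3-benzothiazol-2-yl where furan-2-yl had been, and the read-out did not move. Compound 2 therefore stands level with compound 1, both at the floor of the read-out with no inhibition detected.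

Compound 3, `COc1ccc(C2CC(c3ccc(Cl)cc3)=NN2C(=O)c2nc3ccccc3s2)cc1`, keeps the 1,3-benzothiazol-2-yl group of compound 2 and changes a different part of the molecule: chloro in place of hydrogen on an aromatic carbon. Going by the values given here, no measured step touches this ring, so the single known step, which was flat, gives no direct guidance; it shows only that one exchange of groups on this core left the read-out unchanged. With compound 1 giving 0% and compound 2 giving 0% in this assay, no movement beyond the scatter is expected for compound 3.

Compound 3 is thus estimated to give 2%, with a range from 0% to 15%. The expected step is a number 2 percentage points higher from compound 2 to compound 3 (within the scatter), that is, essentially none.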

Compound 3, a percentage reported as inhibition, at one concentration (the size of the read-out at that concentration, not a potency): 0%
Compound 3: middle estimate off by 2 percentage points, on the high side; low and high end bracket the measured number.
By their numbers in this assay, from the lowest: compounds 1, 2 and 3 (each within the scatter of the next).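

With this result, a second place on the shared core has been probed: chloro in place of hydrogen on an aromatic carbon, para to a large group, gives no change at the digits printed from compound 2 to compound 3 (within the scatter) in this assay. The earlier step touched only the group on the carbonyl carbon, so exchanges at two separate places have now left the read-out at its floor, although each place has been changed only once. A read-out at its floor can show a gain but not a loss, so this step shows that the 4-chlorophenyl group brings no detectable inhibition at the one concentration tested, and it cannot show whether the change moved the compound further from activity. No measurement is available that would explain this flat result.

The compounds shown leave open whether any other group on this ring, such as an amine, a carboxylic acid or a longer alkyl chain, would lift the read-out off its floor. They also leave open whether changing both places together would give any measurable inhibition in this assay.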